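Extending the Thioether Chain by One Carbon

The source may report more compounds than this note shows. Statements on the series, on what has been measured and on what is new or still open speak of the compounds shown alone.

Compound 3 `CCCCCCCCCCCCCCCSC[C@H](NC(C)=O)C(=O)CCl` gives 8900 nM in a functional assay on NALM-6 cells (Homo sapiens) (a higher number here means a weaker inhibitor, a lower number a stronger inhibitor), the highest number of the three measured, though its gap to compound 1 stays within the scatter. Compound 1 `CCCCCCCCCCSC[C@H](NC(C)=O)C(=O)CCl` gives 4700 nM, and compound 2 `CCCCCCCCCCCSC[C@H](NC(C)=O)C(=O)CCl` gives 1700 nM; a 1.9-fold higher number from compound 1 to compound 3 (0.28 log units; within the scatter) lies within the scatter, whereas a 5.2-fold higher number from compound 2 to compound 3 (0.72 log units; beyond the scatter) does not. Compound 4 `CCCCCCCCCCCCCCCCSC[C@H](NC(C)=O)C(=O)CCl` differs from compound 3 by methyl in place of hydrogen on a saturated chain carbon, ten or more bonds along the chain from a sulfur. Going by the values given here, the closest precedent is a 2.8-fold lower number from compound 1 to compound 2 (0.44 log units; beyond the scatter), the only other methyl-for-hydrogen step, yet a 5.2-fold higher number from compound 2 to compound 3 (0.72 log units; beyond the scatter) ran the opposite way with a butyl, so no steady trend emerges from these three compounds. The expected step is therefore a 1.1-fold higher number from compound 3 to compound 4 (0.05 log units; within the scatter), not beyond the scatter. For compound 4 the estimate is 10000 nM, with a range from 4000 nM to 25000 nM.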

Compound 4, half-maximal inhibitory concentration: 16000 nM
Estimate against measurement, compound 4: 1.6-fold (0.20 log units) below, within the range that was stated.
By their numbers in this assay, from the lowest: compound 2; then compounds 1, 3 and 4 (each within the scatter of the next, the first and the last beyond it).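

The same methyl-for-hydrogen change on a saturated chain carbon does not carry over from one chain length to another in this assay: (the same change on two cores in this assay, a 2.8-fold lower number (0.44 log units; beyond the scatter) from compound 1 to compound 2 and a 1.8-fold higher number (0.25 log units; within the scatter) from compound 3 to compound 4, 5.0-fold (0.70 log units) apart, beyond the scatter of two such steps). The longest chain shows a clear loss against the two shortest (a 9.4-fold higher number from compound 2 to compound 4 (0.97 log units; beyond the scatter)) and (a 3.4-fold higher number from compound 1 to compound 4 (0.53 log units; beyond the scatter)), whereas the last extension alone remains unresolved (a 1.8-fold higher number from compound 3 to compound 4 (0.25 log units; within the scatter)). Compound 2 therefore stands as the strongest inhibitor of the four. Going by these compounds, whether a longer chain would continue this loss, and how an amine or a carboxylic acid at the chain end would behave, remains open.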